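Trimethoxy Isomer Swap on the Ester Aryl Group

The compounds below may be only part of what the source reports. "The series", "measured", "known", "first", "only" and "open" are said of these compounds alone.

In a functional assay on HL-60 cells (Homo sapiens) for cytotoxicity, read by MTT assay, with a stated time of 24 h (on this read-out higher numbers stand for weaker inhibition and lower numbers for stronger inhibition), the three measured compounds stand as follows.
Compound 1, `COC(=O)/C(=C\c1ccc(OC(=O)c2ccccc2)cc1)Sc1ccnc2cc(Cl)ccc12`, gives 30200 nM.
Compound 2, `COC(=O)/C(=C\c1ccc(OC(=O)c2c(OC)cccc2OC)cc1)Sc1ccnc2cc(Cl)ccc12`, gives 37200 nM.
Compound 3, `COC(=O)/C(=C\c1ccc(OC(=O)c2cc(OC)c(OC)c(OC)c2)cc1)Sc1ccnc2cc(Cl)ccc12`, gives 4240 nM.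

Compound 3 holds the lowest number of the three, and both of its steps from the others lie beyond the scatter: a 7.1-fold lower number from compound 1 to compound 3 (0.85 log units; beyond the scatter) and an 8.8-fold lower number from compound 2 to compound 3 (0.94 log units; beyond the scatter). By contrast, a 1.2-fold higher number from compound 1 to compound 2 (0.09 log units; within the scatter) shows no separation between compound 1 and compound 2.

Compound 4, `COC(=O)/C(=C\c1ccc(OC(=O)c2ccc(OC)c(OC)c2OC)cc1)Sc1ccnc2cc(Cl)ccc12`, differs from compound 3 only in the arrangement of the same atoms: 2,3,4-trimethoxyphenyl in place of 3,4,5-trimethoxyphenyl on a carbonyl carbon. Among the compounds with values here, no measured step moves the methoxy groups around the ring in this way, so the two steps that bear on it do so only indirectly. The gain seen on going from compound 1 to compound 3 came with the 3,4,5-pattern, while the 2,6-pattern of compound 2 brought none. A weakening relative to compound 3 is therefore expected, with compound 4 estimated at 9000 nM (range 3000 nM to 30000 nM), an expected step of a 2.1-fold higher number from compound 3 to compound 4 (0.33 log units; beyond the scatter).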

Compound 4, half-maximal inhibitory concentration: 2080 nM
Compound 4: middle estimate off by 4.3-fold (0.64 log units), on the high side; the whole stated range lies above it.
By their numbers in this assay, from the lowest: compound 4; then compound 3; then compounds 1 and 2 (each within the scatter of the next).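

Within the data shown here, with the same methoxy groups on the ring, the 2,3,4-trimethoxyphenyl group on this carbonyl carbon gives a 2.0-fold lower number from compound 3 to compound 4 (0.31 log units; beyond the scatter) in this assay, so the arrangement alone shifts the read-out and the 3,4,5-trimethoxyphenyl pattern is not the only one that lowers the number. Both trimethoxyphenyl groups now stand clearly below the phenyl group, and compound 4 shows large steps on both earlier references (a 15-fold lower number from compound 1 to compound 4 (1.16 log units; beyond the scatter) and an 18-fold lower number from compound 2 to compound 4 (1.25 log units; beyond the scatter)), while the 2,6-dimethoxyphenyl group of compound 2 goes against any simple rule that methoxy groups lower the number here.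

As far as these compounds go, whether this order would hold with ethoxy or hydroxyl groups in place of the methoxy groups remains open. Nothing available accounts for why the 2,3,4-trimethoxyphenyl and 2,6-dimethoxyphenyl groups differ so widely.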